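Swapping an Aryl for a Benzyl on a Piperazine

The compounds below may be only part of what the source reports. "The series", "measured", "known", "first", "only" and "open" are said of these compounds alone.

Measured compounds:
compound 1 `CCOc1nc(N)nc2ncc(-c3ccc(Cl)c(Cl)c3)nc12` — > 10000 nM
compound 2 `COc1ccc(-c2cnc3nc(N)nc(N4CCN(c5ccc(F)cc5)CC4)c3n2)cc1OC` — 100 nM

Of the compounds shown here, two have been tested in a functional assay on cells (T-cell, Homo sapiens) for inhibition; a higher number here means a weaker inhibitor, a lower number a stronger inhibitor. For compound 1 the result is a limit of the assay rather than a number, > 10000 nM. In this assay compound 2 gives 100 nM, the only numerical value in this set, so compound 2 stands alone among the shown numbers, while the other entry sits at the limit of > 10000 nM in this assay, at which 1 of the 2 values shown sits. Within the data shown here, no pair of measured compounds differs in a single place, so no measured step is available to lean on.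

Compound 3 `COc1ccc(-c2cnc3nc(N)nc(N4CCN(Cc5ccccc5)CC4)c3n2)cc1OC` has not been measured. It differs from compound 2 in one place: benzyl in place of 4-fluorophenyl on an amine nitrogen in a ring. Among the measured compounds shown here, with no measured step to guide it, a modest weakening, beyond the scatter but not large, is expected. The expected step from compound 2 to compound 3 is a 3.0-fold higher number from compound 2 to compound 3 (0.48 log units; beyond the scatter). Compound 3 is estimated to give 300 nM, within a range from 60 nM to 1500 nM.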

Compound 3, half-maximal inhibitory concentration: 900 nM
Compound 3: the middle estimate sits 3.0-fold (0.48 log units) below what was measured; low and high end bracket the measured number.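

In this assay, the swap of 4-fluorophenyl for benzyl on the amine nitrogen in a ring gives a 9.0-fold higher number from compound 2 to compound 3 (0.95 log units; beyond the scatter). This shows that the position responds to the choice of group, even though both groups have the same number of heavy atoms and each carries one six-membered aromatic ring of carbon only. Nothing measured here accounts for the size of this step.

The swap changes two things at once, adding a carbon to the group and removing its fluorine, so the compounds shown cannot say which of the two matters. A plain phenyl or a 4-fluorobenzyl on the same nitrogen would separate these two changes, and a longer chain carrying the aromatic ring would show how the trend continues.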